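Bromo in Place of Nitro Across Two Pairs

This account rests on a few compounds, and the source may have more. Where it says the series, first, only, none or still open, it means among the compounds named here.

Measured so far:
Compound 1, `Cc1noc(NS(=O)(=O)c2ccc(NC(=O)c3cc4cc([N+](=O)[O-])ccc4oc3=O)cc2)c1C`, gives 15000 nM in a functional assay on HepG2 cells (Homo sapiens) for antiproliferative activity, read by fluorescence and resazurin assay, with a stated time of 48 h; a lower number here means a stronger inhibitor, a higher number a weaker inhibitor.
Compound 2, `Cc1noc(NS(=O)(=O)c2ccc(NC(=O)c3cc4cc(Br)ccc4oc3=O)cc2)c1C`, gives 8800 nM in this assay.
Compound 3, `O=C(N/N=C/c1cccnc1)c1cc2cc([N+](=O)[O-])ccc2oc1=O`, gives 17000 nM in this assay.

Compound 1 and compound 2 differ in one place, (bromo in place of nitro on an aromatic carbon), and the step between them is a 1.7-fold lower number from compound 1 to compound 2 (0.23 log units; within the scatter). Compound 4, `O=C(N/N=C/c1cccnc1)c1cc2cc(Br)ccc2oc1=O`, is not yet measured; it differs from compound 3 in the same way, (bromo in place of nitro on an aromatic carbon), and the place is the same, so this is the same change. How the core of compound 3 differs from the core of compound 1 is not broken down here. The values of compound 1 and compound 3 lie within the scatter of each other. For compound 4 the expected step is a 1.7-fold lower number from compound 3 to compound 4 (0.23 log units; within the scatter), resting on the earlier step of a 1.7-fold lower number from compound 1 to compound 2 (0.23 log units; within the scatter) applied to compound 3 at 17000 nM. Compound 4 is therefore estimated at 10000 nM, between 4500 nM and 23000 nM.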

Compound 4, half-maximal inhibitory concentration: 19000 nM
For compound 4 the middle estimate is 1.9-fold (0.28 log units) below the measured one; low and high end bracket the measured number.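

The new step in this assay is a 1.1-fold higher number from compound 3 to compound 4 (0.05 log units; within the scatter) and, set beside the earlier one, it gives the same reading on both cores: the same change on two cores in this assay, a 1.7-fold lower number (0.23 log units; within the scatter) from compound 1 to compound 2 and a 1.1-fold higher number (0.05 log units; within the scatter) from compound 3 to compound 4, 1.9-fold (0.28 log units) apart, within the scatter of two such steps. Bromo in place of nitro on an aromatic carbon therefore moved the number beyond the scatter on neither core, and the two cores do not differ in their response to this change. This does not show that the change has any real effect on either core, nor that the steps are equal, only that this assay cannot tell them apart.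

The compounds shown leave open whether another group at this place, such as an amine, a methoxy group or a carboxylic acid, would move the number beyond the scatter. They also leave open whether the same swap would behave alike on any other core.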